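From benzylcarbamoyl to dimethylcarbamoyl on a shared core

This account rests on a few compounds, and the source may have more. Where it says the series, first, only, none or still open, it means among the compounds named here.

Measured in a functional assay on MDA-MB-231 cells (Homo sapiens) for cytotoxicity, read by MTT assay, with a stated time of 24 h; on this read-out higher numbers stand for weaker inhibition and lower numbers for stronger inhibition:
compound 1 `Fc1ccc(-c2nc3cccnc3n2C2CCCC2)cc1`: 500 nM
compound 2 `c1ccc(Oc2ccc(-c3nc4cccnc4n3C3CCCC3)cc2)cc1`: > 10000 nM (a limit of the assay)
compound 3 `O=C(NCc1ccccc1)c1ccc(-c2nc3cccnc3n2C2CCCC2)cc1`: 620 nM

Compound 3 stands level with the fluoro member of the series, the step being a 1.2-fold higher number from compound 1 to compound 3 (0.09 log units; within the scatter). Compound 2 gives only a limit, > 10000 nM. The two steps that reach this phenoxy compound are both large: an at least 20-fold higher number from compound 1 to compound 2 (1.30 log units; beyond the scatter) and an at least 16-fold lower number from compound 2 to compound 3 (1.20 log units; beyond the scatter).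

Compound 4 `CN(C)C(=O)c1ccc(-c2nc3cccnc3n2C2CCCC2)cc1` has not yet been measured. The change is dimethylamino in place of benzylamino on a carbonyl carbon; in words, dimethylamino in place of benzylamino on a carbonyl carbon. Within the data shown here, no measured step alters the group on this carbonyl carbon, so the nearest guidance comes from changes on the aromatic carbon. The step of a 1.2-fold higher number from compound 1 to compound 3 (0.09 log units; within the scatter) points to no step beyond the scatter in this assay, with a slight lean towards a higher number. The step of an at least 20-fold higher number from compound 1 to compound 2 (1.30 log units; beyond the scatter) shows that a change in this part of the series can be large, so the upper end stays wide. The expected change is a 1.3-fold higher number from compound 3 to compound 4 (0.11 log units; within the scatter). For compound 4 the estimate is 800 nM, with an expected range from 300 nM to 3500 nM.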

Compound 4, half-maximal inhibitory concentration: 520 nM
For compound 4 the middle estimate is 1.5-fold (0.19 log units) above the measured one, within the range that was stated.
By their numbers in this assay, from the lowest: compounds 1, 4 and 3 (each within the scatter of the next). At a limit, above all of these: compound 2.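

In this assay, the carbonyl carbon tolerates a large change in the group it carries: with dimethylamino in place of benzylamino the step is a 1.2-fold lower number from compound 3 to compound 4 (0.08 log units; within the scatter), so neither the aromatic ring of benzylamino nor the amide hydrogen is needed to hold this level on the shared core. Compound 4 also stands level with the fluoro member, the step being a 1.0-fold higher number from compound 1 to compound 4 (0.02 log units; within the scatter), so the two amides and the fluoro group read alike on the aromatic carbon, while compound 2 goes against this. The step to the new amide from the phenoxy member is an at least 19-fold lower number from compound 2 to compound 4 (1.28 log units; beyond the scatter), and it starts from a limit of the assay, not from a number: the limit of > 10000 nM in this assay, at which 1 of the 4 values shown sits.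

The compounds shown leave open whether a plain amino group, a ring amine such as morpholine or a longer chain on the carbonyl carbon would hold the same level, and whether a carboxylic acid would do so in place of the amide. They also do not tell why the phenoxy member alone stands apart from the other three.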